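Lengthening the Core Chain from Ethyl to Propyl

A few compounds are considered here, and "the series" means these few. Any claim that something is new, unique, unknown or untested is made for them only; others in the source may bear on it.

Compound 2 `CCc1c(OC)nc2nc(-c3nnc(C)o3)cn2c1C` has the lowest number of the three compounds measured in a functional assay on the whole organism with Rattus norvegicus as the target; a higher number here means that more compound is needed for the effect, a lower number that less compound is needed. In this assay compound 2 gives 2 mg/kg. Compound 1 `CCCc1c(OC)nc2nc(-c3noc(C)n3)cn2c1C` lies nearest, and in this assay compound 1 gives 5 mg/kg. Compound 3 `CCCc1nnc(-c2cn3c(C)c(CC)c(OC)nc3n2)o1` lies furthest, and in this assay compound 3 gives 50 mg/kg. Compound 4 `CCCc1c(OC)nc2nc(-c3nnc(C)o3)cn2c1C` has not been measured; it differs from compound 2 in one place (methyl in place of hydrogen on a saturated chain carbon, two bonds along the chain from an aromatic carbon). Within the data shown here, the only measured step that also lengthens a chain is a 25-fold higher number from compound 2 to compound 3 (1.40 log units; beyond the scatter), but there ethyl enters in place of hydrogen, and at a carbon bound to an aromatic carbon rather than two bonds along the chain, so it bears only loosely here. A milder outcome is expected for compound 4 because compound 1 gives 5 mg/kg while carrying the same propyl chain as compound 4 and differing from it only in the second ring. A small move toward a higher number is therefore expected, within the scatter: a 2.0-fold higher number from compound 2 to compound 4 (0.30 log units; within the scatter). Compound 4 is estimated at 4 mg/kg, between 1.5 mg/kg and 12 mg/kg.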

Compound 4, minimum effective dose: 10 mg/kg
Beside the measured number, compound 4's estimate is 2.5-fold (0.40 log units) below it; the range from low to high includes it.
By their numbers in this assay, from the lowest: compound 2; then compounds 1 and 4 (each within the scatter of the next); then compound 3.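

On the shared core, replacing ethyl with propyl adds a single methyl and gives (a 5.0-fold higher number from compound 2 to compound 4 (0.70 log units; beyond the scatter)), so in this assay even this small lengthening of the chain on the core moves the dose beyond the scatter. With propyl in place, 5-methyl-1,3,4-oxadiazol-2-yl in place of 5-methyl-1,2,4-oxadiazol-3-yl gives (a 2.0-fold higher number from compound 1 to compound 4 (0.30 log units; within the scatter)), so this assay does not separate these two groups when they are carried with that chain. Nothing available explains why the extra methyl has this effect.

From the compounds shown here alone, it remains open whether a methyl or a butyl chain at this place would continue the same trend, and whether an isopropyl, a hydroxyl or an amine on the chain would behave differently. Going by these compounds, the size of the ethyl to propyl step with 5-methyl-1,2,4-oxadiazol-3-yl also remains unknown.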